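Cytotoxicity notes for the step from compound 3 to compound 4

A few compounds are considered here, and "the series" means these few. Any claim that something is new, unique, unknown or untested is made for them only; others in the source may bear on it.

Compound 3 `Cc1cc(-n2ccc3ccccc32)cn2c(CSCCc3ccccc3)cnc12` in an ADME assay on HEL cells (Homo sapiens) for cytotoxicity, with a stated time of 3 days (on this read-out lower numbers stand for higher toxicity in this test and higher numbers for lower toxicity in this test), gives > 20 ug/mL, which is a limit of the test and not a number. The two other measured members sit at a full number: compound 1 `C=Cc1ccc(-c2cc(C)c3ncc(CSCCc4ccccc4)n3c2)cc1` gives 20 ug/mL in this assay, and compound 2 `Cc1cc(N2CCN(C)CC2)cn2c(CSCCc3ccccc3)cnc12` gives 20 ug/mL. Of the three values, (the limit of > 20 ug/mL in this assay, at which 1 of the 3 values shown sits).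

The change to compound 4 `Cc1cc(Sc2ccc(O)cc2)cn2c(CSCCc3ccccc3)cnc12` is (4-hydroxyphenyl)sulfanyl in place of 1H-indol-1-yl on an aromatic carbon. From the compounds shown here alone, the steps that reach compound 3 are a number no lower from compound 1 to compound 3 (the limit leaves the size open) and a number no lower from compound 2 to compound 3 (the limit leaves the size open); both end at the limit, so their size stays open. Among the compounds with values here, the only step between two full numbers, no change at the digits printed from compound 1 to compound 2 (within the scatter), lies within the scatter. Within the data shown here, three rather different substituents on the same aromatic carbon thus give values at or past the same figure, and no step in the set is beyond the scatter. The step of a number no higher from compound 3 to compound 4 (the limit leaves the size open) is therefore expected to be none beyond the scatter. Compound 4 is estimated at 20 ug/mL in this assay, with a range from 10 ug/mL to 40 ug/mL, and a fair chance that only a limit is again reported.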

Compound 4, minimum cytotoxic concentration: 4 ug/mL
For compound 4 the middle estimate is 5.0-fold (0.70 log units) above the measured one, and the stated range ends above it.
By their numbers in this assay, from the lowest: compound 4; then compounds 1 and 2 (each within the scatter of the next).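

In this assay, within the data shown here, this aromatic carbon, two atoms from the ring nitrogen, proves sensitive to its substituent for the first time, with (4-hydroxyphenyl)sulfanyl giving a 5.0-fold lower number from compound 1 to compound 4 (0.70 log units; beyond the scatter) and a 5.0-fold lower number from compound 2 to compound 4 (0.70 log units; beyond the scatter) and also an at least 5.0-fold lower number from compound 3 to compound 4 (0.69 log units; beyond the scatter) in the direction of higher toxicity in this test. Compound 3 holds a limit of the test and not a number, so the last of these steps fixes only a smallest size. The 4-vinylphenyl, 4-methylpiperazin-1-yl and 1H-indol-1-yl groups thus stay apart from (4-hydroxyphenyl)sulfanyl, though nothing at hand gives a reason for this shift.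

Open, from the compounds shown here alone, is whether the sulfur link or the hydroxyl carries the shift. A phenylsulfanyl group without the hydroxyl, a 4-methoxyphenylsulfanyl group and a 4-hydroxyphenyl group joined directly to the ring would separate the two.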